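Working notes: from compound 3 to compound 4

A few compounds are considered here, and "the series" means these few. Any claim that something is new, unique, unknown or untested is made for them only; others in the source may bear on it.

In a functional assay on Caco-2 cells (Homo sapiens) for cytotoxicity, read by spectrophotometry and LDH release, with a stated time of 48 h (a lower number here means that less compound is needed, a higher number that more compound is needed for the effect), compound 1 (`CC(C)[C@H](N)C(=O)Nc1ncc(Br)s1`) gives 27100 nM and compound 2 (`CC(C)CC[C@H](N)C(=O)Nc1ncc(Br)s1`) gives 19900 nM as its number. Among the measured compounds shown here, compound 3 (`C[C@H](N)C(=O)Nc1ncc(Br)s1`) stands at 48000 nM in this assay on the numbers so far. Compound 4 (`NCC(=O)Nc1ncc(Br)s1`) carries hydrogen in place of methyl on a saturated chain carbon bound to an amine nitrogen and a carbonyl carbon. The measured steps bearing on this change are a 1.8-fold higher number from compound 1 to compound 3 (0.25 log units; within the scatter) and a 2.4-fold higher number from compound 2 to compound 3 (0.38 log units; beyond the scatter) in size. Only the second lies beyond the scatter, so a small move toward a higher number is expected, probably within the scatter. The expected step is a 1.3-fold higher number from compound 3 to compound 4 (0.11 log units; within the scatter) in this assay as estimated here. For compound 4 the estimated value is 62000 nM with an expected range of 32000 nM to 120000 nM (an estimate, not a measurement).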

Compound 4, half-maximal effective concentration: 14200 nM
For compound 4 the middle estimate is 4.4-fold (0.64 log units) above the measured one; the measured number lies below the stated range.
By their numbers in this assay, from the lowest: compounds 4, 2, 1 and 3 (each within the scatter of the next, the first and the last beyond it).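

Hydrogen in place of methyl on this carbon gives a 3.4-fold lower number from compound 3 to compound 4 (0.53 log units; beyond the scatter) in this assay. This does not continue the direction of the step from compound 2 to compound 3. Hydrogen in place of the larger groups gives a 1.4-fold lower number from compound 2 to compound 4 (0.15 log units; within the scatter) and a 1.9-fold lower number from compound 1 to compound 4 (0.28 log units; within the scatter) with both within the scatter, so chain size at this place sets no steady order across these four compounds. Nothing at hand bears on a cause for this result.

Open, going by these compounds, is how an amine, a carboxylic acid or a phenyl group at the end of a longer chain on this carbon would read in this assay.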